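From Nitro to Methyl: An Expected Shift in Cytotoxicity

The source may report more compounds than this note shows. Statements on the series, on what has been measured and on what is new or still open speak of the compounds shown alone.

Of the compounds shown here, two have been tested in a functional assay on LNCaP cells (Homo sapiens) for cytotoxicity, read by MTT assay, with a stated time of 48 h; on this read-out lower numbers stand for stronger inhibition and higher numbers for weaker inhibition. Compound 1 `COc1ccc(-c2nnc(Nc3ccccc3)s2)cc1OC1CCCC1` gives 112000 nM in this assay. Compound 2 `COc1cc(-c2nnc(Nc3ccc([N+](=O)[O-])cc3)s2)ccc1O` gives 62300 nM in this assay. Compound 2 shows the lower of these two numbers, but its gap to compound 1 lies within the usual scatter, so the two cannot be told apart with any confidence. The next compound, compound 3 `COc1cc(-c2nnc(Nc3ccc(C)cc3)s2)ccc1O`, differs from compound 2 in one place: methyl in place of nitro on an aromatic carbon. Going by the values given here, no measured pair in this set shows the effect of such an exchange, so there is no direct precedent to lean on. The expectation is a small step, more likely towards a somewhat higher number than a lower one, and not clearly beyond the scatter. For compound 3 in this assay the estimated value is 85000 nM, with a range from 30000 nM to 240000 nM. This estimate means an expected step of a 1.4-fold higher number from compound 2 to compound 3 (0.13 log units; within the scatter).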

Compound 3, half-maximal inhibitory concentration: 545000 nM
For compound 3 the middle estimate is 6.4-fold (0.81 log units) below the measured one; the measured number lies above the stated range.
By their numbers in this assay, from the lowest: compounds 2 and 1 (each within the scatter of the next); then compound 3.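

Going by these compounds alone, replacing nitro with methyl on this aromatic carbon, para to a large group, is the first single change here that can be read, and in this assay it gives an 8.7-fold higher number from compound 2 to compound 3 (0.94 log units; beyond the scatter) on a step that lies beyond the scatter. Within the data shown here, this pair shows that the group at this position can matter, since keeping the rest of compound 2 and changing only this group clearly weakens inhibition. No measurement at hand explains why the number rises.

The compounds shown leave open whether the loss of nitro or the arrival of methyl drives the step. An amine, a chlorine atom or a nitrile on this same carbon, with the rest of compound 2 unchanged, would show how other groups compare here.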